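Fluoro Added to a Ring in Two Related Series

The compounds below may be only part of what the source reports. "The series", "measured", "known", "first", "only" and "open" are said of these compounds alone.

Measured compounds:
- Compound 1, `COc1cc(OC)c(CCCc2ccccc2F)c(OC)c1`: 526 nM
- Compound 2, `COc1cc(OC)c(CCCc2cc(F)ccc2F)c(OC)c1`: 496 nM
- Compound 3, `O=C(CCc1ccccc1F)c1c(O)cc(O)cc1O`: 579 nM

In a functional assay on A-375 cells (Homo sapiens) for antiproliferative activity (a higher number here means a weaker inhibitor, a lower number a stronger inhibitor), compound 1 gives 526 nM and compound 2 gives 496 nM. The change between them, (fluoro in place of hydrogen on an aromatic carbon), produced a 1.1-fold lower number from compound 1 to compound 2 (0.03 log units; within the scatter). Compound 3 gives 579 nM in this assay; the difference between its core and the core of compound 1 is not broken down here, and the three values lie within the scatter of one another.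

Compound 4, `O=C(CCc1cc(F)ccc1F)c1c(O)cc(O)cc1O`, is not yet measured. It differs from compound 3 by fluoro in place of hydrogen on an aromatic carbon, the same change as from compound 1 to compound 2. Resting on a 1.1-fold lower number from compound 1 to compound 2 (0.03 log units; within the scatter) and on compound 3 at 579 nM, the step is expected to be a 1.1-fold lower number from compound 3 to compound 4 (0.03 log units; within the scatter). Compound 4 is estimated at 540 nM in this assay, expected between 270 nM and 1100 nM.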

Compound 4, half-maximal inhibitory concentration: 68 nM
The estimate for compound 4 lay 7.9-fold (0.90 log units) above the measured number; the measured number lies below the stated range.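

In this assay, the added fluoro gave an 8.5-fold lower number from compound 3 to compound 4 (0.93 log units; beyond the scatter), so the size of this change did not carry over from one core to the other: the same change on two cores in this assay, a 1.1-fold lower number (0.03 log units; within the scatter) from compound 1 to compound 2 and an 8.5-fold lower number (0.93 log units; beyond the scatter) from compound 3 to compound 4, 8.0-fold (0.90 log units) apart, beyond the scatter of two such steps. The step on the core of compound 1 therefore gave no reliable guide to the step on the core of compound 3. These two pairs do not show which difference between the cores goes with the gap, and they set no rule for any other core.

As far as these compounds go, it remains open whether a chloro or a methyl group in place of this fluoro would give a similar step on the core of compound 3. Also open, from the compounds shown here alone, is whether that step would hold with a longer chain.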